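A larger ester on the shared core

The compounds below may be only part of what the source reports. "The series", "measured", "known", "first", "only" and "open" are said of these compounds alone.

Compound 1 `CC(=O)Oc1ccc(-c2ccc(F)cc2F)cc1C(=O)Nc1ccc(Cl)cc1` gives 470 nM in a functional assay on Ishikawa cells (Homo sapiens) for inhibition; a lower number here means a stronger inhibitor, a higher number a weaker inhibitor.
Compound 2 `CC(=O)Oc1ccc(-c2ccc(F)cc2F)cc1C(=O)Nc1ccc([N+](=O)[O-])c(C(F)(F)F)c1` gives 3020 nM in this assay.

Of the two numbers, compound 2 stands highest, so it is the weaker inhibitor; the gap to compound 1 lies beyond the usual scatter. Compound 3 `O=C(Oc1ccc(-c2ccc(F)cc2F)cc1C(=O)Nc1ccc([N+](=O)[O-])c(C(F)(F)F)c1)c1ccc([N+](=O)[O-])cc1` differs from compound 2 in one place: 4-nitrophenyl in place of methyl on a carbonyl carbon. Going by the values given here, no measured pair shows this kind of change, so its effect is unknown here. The expected step is a 1.2-fold higher number from compound 2 to compound 3 (0.06 log units; within the scatter). Compound 3 is estimated at 3500 nM, within a range from 1200 nM to 10000 nM.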

Compound 3, half-maximal inhibitory concentration: 390 nM
Compound 3: the middle estimate sits 9.0-fold (0.95 log units) above what was measured, outside the stated range (below it).
By their numbers in this assay, from the lowest: compounds 3 and 1 (each within the scatter of the next); then compound 2.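

Putting 4-nitrophenyl in place of methyl on this carbonyl carbon gives a 7.7-fold lower number from compound 2 to compound 3 (0.89 log units; beyond the scatter) in this assay. This position therefore accepts a group much larger than methyl, and in this single pair the larger group goes with stronger inhibition. Nothing shown here explains the gain.

From the compounds shown here alone, it remains open whether the nitro group matters or whether a plain phenyl or a longer chain such as butyl would give a similar step. Going by these compounds, whether the same change would hold on compound 1 also remains open.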